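Adding a Phenylsulfonyl Group to Compound 3

The source may report more compounds than this note shows. Statements on the series, on what has been measured and on what is new or still open speak of the compounds shown alone.

Measured in a functional assay on SK-OV-3 cells (Homo sapiens) for cytotoxicity, read by MTT assay, with a stated time of 3 days; a lower number here means a stronger inhibitor, a higher number a weaker inhibitor:
Compound 1 `N#Cc1c(NN)nc(SCc2nc3ccccc3[nH]2)nc1-c1ccccc1`: 2.7 nM
Compound 2 `N#Cc1c(Nc2ccccc2)nc(SCc2nc3ccccc3[nH]2)nc1-c1ccccc1`: 4.46 nM
Compound 3 `N#Cc1c(-c2ccccc2)nc(SCc2nc3ccccc3[nH]2)nc1N1CCNCC1`: 2.63 nM

The three compounds lie within the scatter of one another, so compound 3, at 2.63 nM, stands level with both others. Compound 4 `N#Cc1c(-c2ccccc2)nc(SCc2nc3ccccc3[nH]2)nc1N1CCN(S(=O)(=O)c2ccccc2)CC1` carries phenylsulfonyl in place of hydrogen on an amine nitrogen in a ring, the six-membered non-aromatic ring with 2 nitrogen of compound 3: phenylsulfonyl in place of hydrogen on an amine nitrogen in a ring.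

Within the data shown here, no measured step touches this nitrogen. The nearest evidence is a 1.0-fold lower number from compound 1 to compound 3 (0.01 log units; within the scatter) and a 1.7-fold lower number from compound 2 to compound 3 (0.23 log units; within the scatter), together with a 1.7-fold higher number from compound 1 to compound 2 (0.22 log units; within the scatter). All three changed the group on the aromatic carbon or its nitrogen, and all stayed within the scatter. As far as these compounds go, on that evidence no step beyond the scatter is expected in this assay, although the new group itself is untested, so the range is kept wide.

The expected step is a 1.3-fold higher number from compound 3 to compound 4 (0.12 log units; within the scatter). For compound 4 the estimated value is 3.5 nM, with an expected range of 1.2 nM to 10 nM.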

Compound 4, half-maximal inhibitory concentration: 2.77 nM
The estimate for compound 4 lay 1.3-fold (0.10 log units) above the measured number; the range from low to high includes it.
By their numbers in this assay, from the lowest: compounds 3, 1, 4 and 2 (each within the scatter of the next).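

In this assay, the amine nitrogen in a ring of compound 3 accepted phenylsulfonyl, a group of 9 heavy atoms with one six-membered aromatic ring, in place of hydrogen, giving a 1.1-fold higher number from compound 3 to compound 4 (0.02 log units; within the scatter). Among these compounds, the earlier steps had all changed the group on the aromatic carbon or its nitrogen, so this is the first reading at this nitrogen, and it shows that even this large addition stays within the scatter. No measurement shown here explains this outcome.

As far as these compounds go, whether methyl, acetyl or a chain ending in a carboxylic acid on this nitrogen would also stay within the scatter remains open. Since all four compounds lie within the scatter of their neighbours, the compounds shown also leave open which change to the shared core, if any, would move the number beyond it.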